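Piperidin-1-yl in place of dimethylamino on a saturated ring

A few compounds are considered here, and "the series" means these few. Any claim that something is new, unique, unknown or untested is made for them only; others in the source may bear on it.

Measured so far in a functional assay on MCF7 cells (Homo sapiens) for antiproliferative activity, read by MTT assay, with a stated time of 72 h (a higher number here means a weaker inhibitor, a lower number a stronger inhibitor), as half-maximal inhibitory concentration:
- Compound 1 `COc1cc2c(Nc3ccc(C#N)cc3)ncnc2cc1OCCCN1CCC(c2ccccc2)CC1` gives 9800 nM
- Compound 2 `COc1cc2c(Nc3ccc(C#N)cc3)ncnc2cc1OCCCN1CCC(N(C)C)CC1` gives 31000 nM

Of this pair, compound 2 at 31000 nM has the higher number and is the weaker inhibitor. The next structure, compound 3 `COc1cc2c(Nc3ccc(C#N)cc3)ncnc2cc1OCCCN1CCC(N2CCCCC2)CC1`, differs from compound 2 at one place (piperidin-1-yl in place of dimethylamino on a saturated ring carbon) and carries piperidin-1-yl in place of dimethylamino on a saturated ring carbon. Within the data shown here, only one measured step bears on this place: a 3.2-fold higher number from compound 1 to compound 2 (0.50 log units; beyond the scatter) when phenyl gave way to dimethylamino. Compound 3 again holds a ring there, like compound 1 at 9800 nM, so a partial move back towards that number is expected, though a single step is thin evidence. The expected change is a 2.1-fold lower number from compound 2 to compound 3 (0.32 log units; beyond the scatter) and would be modest, towards a lower number in this assay. For compound 3 the estimate is 15000 nM with an expected range from 6000 nM to 38000 nM in repeated measurements.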

Compound 3, half-maximal inhibitory concentration: 19600 nM
Compound 3: middle estimate off by 1.3-fold (0.12 log units), on the low side; the measured number falls inside the stated range.
By their numbers in this assay, from the lowest: compounds 1, 3 and 2 (each within the scatter of the next, the first and the last beyond it).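

At this saturated ring carbon, going from dimethylamino (3 heavy atoms, no ring) to piperidin-1-yl (6 heavy atoms, one six-membered non-aromatic ring) gives a 1.6-fold lower number from compound 2 to compound 3 (0.20 log units; within the scatter) in this assay and so cannot be told apart from no effect. The comparison with phenyl reads a 2.0-fold higher number from compound 1 to compound 3 (0.30 log units; within the scatter) and likewise separates nothing, so compound 3 sits within the scatter of both neighbours, and the gap seen earlier between compound 1 and compound 2 cannot yet be tied to having a ring at this carbon. No measurement available here explains these numbers.

As far as these compounds go, whether a morpholin-4-yl ring, a hydroxyl group or a primary amine on this carbon would stand clearly apart from these three groups remains open. So does whether a carboxylic acid there would move the number beyond the scatter.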